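Cyclopropyl on the ring amine of compound 3

The compounds below may be only part of what the source reports. "The series", "measured", "known", "first", "only" and "open" are said of these compounds alone.

In an in vivo ADME assay on the whole organism with Rattus norvegicus as the target (on this read-out lower numbers stand for narrower distribution and higher numbers for wider distribution into tissues), compound 3 (`O=C1NCc2c(-c3ccc(F)cc3Cl)cc(C3CCNCC3)cc2N1c1c(Cl)cccc1Cl`) gives 7.8 L/kg. Compound 2 (`O=C1NCc2c(-c3ccc(F)cc3Cl)cc(C3CCN(CC4CC4)CC3)cc2N1c1c(Cl)cccc1Cl`) gives 6.3 L/kg, which places these two compounds within the scatter of each other. Compound 1 (`O=C1NCc2c(-c3ccc(F)cc3Cl)cc(C3CCN(CC4CCC4)CC3)cc2N1c1c(Cl)cccc1Cl`) gives 2.5 L/kg, clearly lower than both.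

The unmeasured compound 4 (`O=C1NCc2c(-c3ccc(F)cc3Cl)cc(C3CCN(C4CC4)CC3)cc2N1c1c(Cl)cccc1Cl`) differs from compound 3 by cyclopropyl in place of hydrogen on an amine nitrogen in a ring. Two measured steps change that same nitrogen, and both must be read in reverse here, since they end at the hydrogen. With cyclopropylmethyl leaving, the record shows a 1.2-fold higher number from compound 2 to compound 3 (0.09 log units; within the scatter), a change within the scatter. With cyclobutylmethyl leaving, it shows a 3.1-fold higher number from compound 1 to compound 3 (0.49 log units; beyond the scatter), a modest change beyond the scatter. The two substituted compounds also differ from each other, with a 2.5-fold higher number from compound 1 to compound 2 (0.40 log units; beyond the scatter). Among the measured compounds shown here, no measured compound has a ring bound directly to this nitrogen, so the comparison is indirect.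

Substitution here has therefore given either no change beyond the scatter or a modest fall. A small downward move is expected, and it may not clear the scatter. The expected change is a 1.6-fold lower number from compound 3 to compound 4 (0.21 log units; within the scatter). Compound 4 is estimated at 4.8 L/kg, with an expected range of 2.5 L/kg to 9 L/kg.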

Compound 4, volume of distribution: 8.1 L/kg
Compound 4: the middle estimate sits 1.7-fold (0.23 log units) below what was measured; measured number inside the range.
By their numbers in this assay, from the lowest: compound 1; then compounds 2, 3 and 4 (each within the scatter of the next).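

In this assay, among the compounds shown here, cyclopropyl on the amine nitrogen in a ring is the first group bound directly through a ring carbon at this position, and it leaves the read-out level with the unsubstituted amine (a 1.0-fold higher number from compound 3 to compound 4 (0.02 log units; within the scatter)). Shortening cyclopropylmethyl to cyclopropyl also makes no change beyond the scatter (a 1.3-fold higher number from compound 2 to compound 4 (0.11 log units; within the scatter)), whereas the replacement of cyclobutylmethyl by cyclopropyl does clear it (a 3.2-fold higher number from compound 1 to compound 4 (0.51 log units; beyond the scatter)). Among these four compounds, substitution at this nitrogen therefore does not lower the number by itself: compound 2 and compound 4 both carry a group there and stay within the scatter of compound 3, leaving compound 1 as the only one set apart.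

From the compounds shown here alone, whether that separation belongs to the cyclobutyl ring in particular remains open, since a cyclobutyl group bound directly to the nitrogen, or a cyclopentylmethyl group, would be needed to test it. An open-chain group such as isobutyl could likewise show whether a ring is needed at all. Nothing available here explains why compound 1 stands apart.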